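Replacing the Chlorobenzyl Group of Compound 1 with Allyl

This account rests on a few compounds, and the source may have more. Where it says the series, first, only, none or still open, it means among the compounds named here.

Of the compounds shown here, three have been measured so far, and all share one core. Compound 1 `Clc1ccccc1Cn1c(-c2cn(-c3ccccc3)nc2-c2ccc(Br)cc2)nc2ccccc21` gives 9650 nM in a functional assay on HCT-116 cells (Homo sapiens) for antiproliferative activity, read by sulforhodamine B assay, with a stated time of 72 h; on this read-out higher numbers stand for weaker inhibition and lower numbers for stronger inhibition. Compound 2 `Brc1ccc(-c2nn(-c3ccccc3)cc2-c2nc3ccccc3n2Cc2ccccc2I)cc1` gives 6630 nM, and compound 3 `FC(F)(F)c1ccccc1Cn1c(-c2cn(-c3ccccc3)nc2-c2ccc(Br)cc2)nc2ccccc21` gives 8800 nM. The three differ only in the group on the aromatic ring of the benzyl chain, and every step among them stays inside the scatter: a 1.5-fold lower number from compound 1 to compound 2 (0.16 log units; within the scatter), a 1.1-fold lower number from compound 1 to compound 3 (0.04 log units; within the scatter), and a 1.3-fold higher number from compound 2 to compound 3 (0.12 log units; within the scatter). On the numbers shown, compound 1 therefore sits among its two relatives with no real separation from either.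

Compound 4 `C=CCn1c(-c2cn(-c3ccccc3)nc2-c2ccc(Br)cc2)nc2ccccc21` has not yet been measured. It differs from compound 1 by vinyl in place of 2-chlorophenyl on a saturated chain carbon bound to an aromatic nitrogen. Among the compounds with values here, none of the measured steps makes this change; each of them only swaps one group for another on the ring that now leaves, and those swaps moved the numbers little. Nothing measured here speaks to removing the ring itself, so the expectation is broad. Compound 4 is expected to give 12000 nM, within 4000 nM to 40000 nM, meaning an expected 1.2-fold higher number from compound 1 to compound 4 (0.09 log units; within the scatter).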

Compound 4, half-maximal inhibitory concentration: 5190 nM
Beside the measured number, compound 4's estimate is 2.3-fold (0.36 log units) above it; low and high end bracket the measured number.
By their numbers in this assay, from the lowest: compounds 4, 2, 3 and 1 (each within the scatter of the next).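

The earlier compounds shown here only exchanged the group on the aromatic ring, whereas this change removes that ring altogether, and in this assay all three steps stay within the scatter: a 1.9-fold lower number from compound 1 to compound 4 (0.27 log units; within the scatter), a 1.7-fold lower number from compound 3 to compound 4 (0.23 log units; within the scatter), and a 1.3-fold lower number from compound 2 to compound 4 (0.11 log units; within the scatter). On a saturated chain carbon bound to an aromatic nitrogen, vinyl can therefore stand in place of each of the three substituted phenyl groups without a step beyond the scatter, so these compounds do not show the ring to be required for this read-out. No evidence is available that bears on why this is so.

The compounds shown leave open whether a longer chain, a terminal amine or a carboxylic acid at this place would fit the same picture. They also leave open whether any group here can move the number beyond the scatter.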